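Unsaturating the Acid Chain of Compound 2

This account rests on a few compounds, and the source may have more. Where it says the series, first, only, none or still open, it means among the compounds named here.

Of the compounds shown here, three have so far been measured in a functional assay on MDA-MB-435S cells (Homo sapiens) for cytotoxicity, read by MTT assay; a higher number here means a weaker inhibitor, a lower number a stronger inhibitor. Compound 1 `CCOC(=O)C(C)Oc1c(-c2ccc(OC)cc2)oc2c(CC=C(C)C)c(O)cc(O)c2c1=O` gives 4100 nM. Compound 2 `COc1ccc(-c2oc3c(CC=C(C)C)c(OCCCC(=O)O)cc(O)c3c(=O)c2O)cc1` gives 12700 nM, and compound 3 `COc1ccc(-c2oc3c(CC=C(C)C)c(OCCCC(=O)O)cc(O)c3c(=O)c2OCCCC(=O)O)cc1` gives 31100 nM. Among these three numbers compound 2 stands second highest: the number for compound 1 is lower than that for compound 2, and the number for compound 3 is higher. For the measured compounds named here, the only step between two compounds that differ in a single place is a 2.4-fold higher number from compound 2 to compound 3 (0.39 log units; beyond the scatter), a modest rise that nevertheless goes beyond the usual scatter.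

Compound 4 `COc1ccc(-c2oc3c(CC=C(C)C)c(OC/C=C/C(=O)O)cc(O)c3c(=O)c2O)cc1` has not yet been measured. It differs from compound 2 in one place: 2-carboxyethenyl in place of 2-carboxyethyl on a saturated chain carbon bound to an oxygen on an aromatic ring. Going by the values given here, no measured step bears directly on this change. The step from compound 2 to compound 3 adds a second 3-carboxypropyl chain on another oxygen and keeps the first chain saturated, so it offers no guide to replacing 2-carboxyethyl with 2-carboxyethenyl. With nothing to point either way, the expected step of a 1.1-fold lower number from compound 2 to compound 4 (0.02 log units; within the scatter) is one that stays within the scatter, in no particular direction. On that basis compound 4 is estimated at 12000 nM, with a range from 5000 nM to 30000 nM.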

Compound 4, half-maximal inhibitory concentration: 11300 nM
Beside the measured number, compound 4's estimate is 1.1-fold (0.03 log units) above it, within the range that was stated.
By their numbers in this assay, from the lowest: compound 1; then compounds 4 and 2 (each within the scatter of the next); then compound 3.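

In this assay, for the compounds shown here, the step of a 1.1-fold lower number from compound 2 to compound 4 (0.05 log units; within the scatter) is the first reading of the acid chain itself, and it shows that a double bond can enter this chain on a saturated chain carbon bound to an oxygen on an aromatic ring while the number stays within the scatter of compound 2. The earlier step of a 2.4-fold higher number from compound 2 to compound 3 (0.39 log units; beyond the scatter) concerned a second 3-carboxypropyl chain on another oxygen, whereas here the heavy atoms, hydrogen-bond donors and hydrogen-bond acceptors all keep their counts and only the double bonds outside aromatic rings differ, so this one change leaves the reading in this assay unmoved. Nothing in the data shown accounts for this flat result.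

From the compounds shown here alone, what an amide in place of the carboxylic acid, or a longer chain carrying that acid, would do at this position remains open. Compound 1 differs from compound 2 in more than one place, so no step shown ties its number to the acid chain.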